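This account rests on a few compounds, and the source may have more. Where it says the series, first, only, none or still open, it means among the compounds named here.

Of the compounds shown here, three sharing one core have been tested so far. Compound 1 `O=C(Nc1cccc(/C=C/C(=O)c2nc3ccccc3[nH]2)c1)c1cccc(Cl)c1` gives 3370 nM in a functional assay on 143B cells (Homo sapiens) for antiproliferative activity, read by MTT assay, with a stated time of 48 h; a higher number here means a weaker inhibitor, a lower number a stronger inhibitor. Compound 2 `O=C(/C=C/c1cccc(NC(=O)c2ccccc2Br)c1)c1nc2ccccc2[nH]1` gives 6050 nM in this assay, and compound 3 `Cc1cccc(C(=O)Nc2cccc(/C=C/C(=O)c3nc4ccccc4[nH]3)c2)c1` gives 4880 nM in this assay. Compound 3 holds the second highest of the three numbers, but its neighbours sit close on either side: the step of a 1.2-fold lower number from compound 2 to compound 3 (0.09 log units; within the scatter) and the step of a 1.4-fold higher number from compound 1 to compound 3 (0.16 log units; within the scatter) both fall inside the usual spread of repeated measurements, as does a 1.8-fold higher number from compound 1 to compound 2 (0.25 log units; within the scatter). On these numbers the three compounds cannot be told apart.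

Compound 4 `O=C(Nc1cccc(/C=C/C(=O)c2nc3ccccc3[nH]2)c1)c1cc(Cl)cc(Cl)c1` is the next member of the series. It differs from compound 3 by 3,5-dichlorophenyl in place of 3-methylphenyl on a carbonyl carbon. Within the data shown here, the steps that bear on this change are those that swap the aryl group on the same carbonyl carbon, a 1.4-fold higher number from compound 1 to compound 3 (0.16 log units; within the scatter) and a 1.2-fold lower number from compound 2 to compound 3 (0.09 log units; within the scatter), and neither moved the number beyond the scatter. Exchanging one halogen or methyl pattern on that ring for another has therefore left this assay essentially unchanged across the measured compounds, and a second chloro on the same ring gives no firm reason to expect otherwise. Compound 4 is accordingly expected to give about 4000 nM in this assay, within a range of 1500 nM to 10000 nM, which means an expected step of a 1.2-fold lower number from compound 3 to compound 4 (0.09 log units; within the scatter).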

Compound 4, half-maximal inhibitory concentration: 3660 nM
Beside the measured number, compound 4's estimate is 1.1-fold (0.04 log units) above it, within the range that was stated.
By their numbers in this assay, from the lowest: compounds 1, 4, 3 and 2 (each within the scatter of the next).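

In this assay the aryl position on the carbonyl carbon now tolerates a disubstituted ring as well as the singly substituted ones: replacing 3-methylphenyl with 3,5-dichlorophenyl gives a 1.3-fold lower number from compound 3 to compound 4 (0.12 log units; within the scatter), and replacing 2-bromophenyl with it gives a 1.7-fold lower number from compound 2 to compound 4 (0.22 log units; within the scatter). The earlier steps shown here only swapped one substituted ring for another, whereas this series now also holds a direct test of adding a substituent, chloro in place of hydrogen on an aromatic carbon, which gives a 1.1-fold higher number from compound 1 to compound 4 (0.04 log units; within the scatter), so across all four compounds no change at this position separates one from another, and none goes against that reading. Nothing measured here accounts for why these numbers stay together.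

The rings shown carry only chloro, bromo and methyl, so what an amine, a hydroxyl or a carboxylic acid on this ring would do in this assay remains open. All four compounds also keep the shared core and the amide unchanged, so these numbers say nothing about how the assay responds to changes there, or whether any change on the ring can move the number beyond the scatter.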